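The source may report more compounds than this note shows. Statements on the series, on what has been measured and on what is new or still open speak of the compounds shown alone.

Measured so far in a physicochemical assay for lipophilicity, read by HPLC, measured as octanol-water partition; on this read-out higher numbers stand for higher lipophilicity and lower numbers for lower lipophilicity:
compound 1 `O=C(OC[C@H]1CN(c2ccc(-n3cc(-c4ccccn4)cn3)c(F)c2)C(=O)O1)c1ccccc1` — 4.21
compound 2 `O=C1O[C@@H](CSc2cccs2)CN1c1ccc(-n2cc(-c3ccccn3)cn2)c(F)c1` — 4.29
compound 3 `COC(=O)NC[C@H]1CN(c2ccc(-n3cc(-c4ccccn4)cn3)c(F)c2)C(=O)O1` — 2.03

Compound 3 sits lowest of the three in this assay, with compound 1 nearest and compound 2 furthest, both well beyond the scatter: a number 2.18 log units lower from compound 1 to compound 3 (beyond the scatter) and a number 2.26 log units lower from compound 2 to compound 3 (beyond the scatter). Between compound 1 and compound 2 the gap is small: a number 0.08 log units higher from compound 1 to compound 2 (within the scatter).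

Compound 4 `O=C1O[C@@H](CNC(=O)C(F)(F)F)CN1c1ccc(-n2cc(-c3ccccn3)cn2)c(F)c1` differs from compound 3 by trifluoromethyl in place of methoxy on a carbonyl carbon. Going by the values given here, no measured step covers this exchange; the two large steps into compound 3 show only that the group on the chain carbon moves this assay strongly, and both ran toward the carbamate. A moderate rise is therefore expected for compound 4, estimated as a number 0.67 log units higher from compound 3 to compound 4 (beyond the scatter). Compound 4 is expected at 2.7, range 2.2 to 3.3.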

Compound 4, partition coefficient: >= 1.78
Compound 4 was reported as a limit; the forecaster's own chance of this, stated with the estimate: 0%; the middle value is on the limit's open side.
By their numbers in this assay, from the lowest: compound 3; then compounds 1 and 2 (each within the scatter of the next).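

In this assay compound 4 gives >= 1.78, a limit and not a number, so its steps from compounds 1, 2 and 3 cannot be read. Going by these compounds, how trifluoromethyl in place of methoxy on a carbonyl carbon shifts this assay remains open.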